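Extending compound 2 with a second aromatic ring

This account rests on a few compounds, and the source may have more. Where it says the series, first, only, none or still open, it means among the compounds named here.

In an assay on RBL-1 cells for inhibition of Polyunsaturated fatty acid 5-lipoxygenase (Rattus norvegicus) (a higher number here means a weaker inhibitor, a lower number a stronger inhibitor), three compounds have numbers. Compound 1 `CCC1CN(c2ccccc2)NC(=O)N1` gives 6900 nM, compound 3 `CC1CN(c2cccc(-c3cccs3)c2)NC(=O)N1` gives 2800 nM, and compound 2 `O=C1NCCN(c2ccccn2)N1` gives 26000 nM, the highest of the three. Compound 1 and compound 3 differ from compound 2 in more than one place, so their values are set beside it only as a frame: compound 3, which carries a further aromatic ring on its aryl group, shows a lower number than compound 1 and than compound 2.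

Compound 4 `O=C1NCCN(c2cccc(-c3ccccn3)n2)N1` is compound 2 with pyridin-2-yl in place of hydrogen on an aromatic carbon. Among the compounds with values here, no measured pair isolates such a change, so the expected size of the step rests on the frame above. The step from compound 2 to compound 4 is expected to be a 3.3-fold lower number from compound 2 to compound 4 (0.51 log units; beyond the scatter), downward and beyond the scatter, because compound 3 with its added aromatic ring gives 2800 nM. Compound 4 is therefore estimated at 8000 nM, with a range from 2500 nM to 25000 nM in this assay.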

Compound 4, half-maximal inhibitory concentration: 6000 nM
Compound 4: the middle estimate sits 1.3-fold (0.12 log units) above what was measured; measured number inside the range.
By their numbers in this assay, from the lowest: compound 3; then compounds 4 and 1 (each within the scatter of the next); then compound 2.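

In this assay, pyridin-2-yl in place of hydrogen on an aromatic carbon, next to the ring nitrogen, gives a 4.3-fold lower number from compound 2 to compound 4 (0.64 log units; beyond the scatter) and this modest step lies beyond the scatter. It is the first pair shown that differs in one place, so the effect of a second aromatic ring at this position of compound 2 can now be read directly rather than from a frame of compounds that differ in several places. The data offer no measured explanation for the step.

As far as these compounds go, it remains open whether an amine, a carboxylic acid or a phenyl ring at this same place would move the number as pyridin-2-yl does. Also open, from the compounds shown here alone, is whether pyridin-2-yl would give a step of similar size on the core of compound 1.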